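Series notes: N-substitution on the shared core

The source may hold more compounds than are shown below. What is called first, only, known or untested is meant among the compounds shown, and "the series" means these compounds.

Measured so far:
compound 1 `COc1cccc2cc(-c3ccccc3)c(O)nc12` — 10000 nM
compound 2 `COc1ccc(-c2cc3c(OC)cc(OC)cc3n(C)c2=O)cc1` — 10000 nM

In a functional assay on MCF7 cells (Homo sapiens) for cytotoxicity, read by colorimetric assay and MTT assay (on this read-out lower numbers stand for stronger inhibition and higher numbers for weaker inhibition), compound 1 gives 10000 nM and compound 2 gives 10000 nM; compound 2 is level with compound 1 at the digits shown, within the scatter. Going by the values given here, no single-point step between measured compounds is available.

Compound 3 `COc1ccc(-c2cc3c(OC)cc(OC)cc3n(CCC(=O)OCc3ccccc3)c2=O)cc1` is not yet measured. It differs from compound 2 by (benzyloxycarbonyl)methyl in place of hydrogen on a saturated chain carbon bound to an aromatic nitrogen. Among the compounds with values here, nothing among the measured compounds speaks to this change, so no step beyond the scatter is expected in this assay, in either direction. For compound 3 the expected value is 10000 nM, with a range from 3000 nM to 30000 nM, which means an expected step of no change at the digits printed from compound 2 to compound 3 (within the scatter).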

Compound 3, half-maximal inhibitory concentration: 10000 nM
Estimate against measurement, compound 3: no gap at the digits printed; the range from low to high includes it.
By their numbers in this assay, from the lowest: compounds 1, 2 and 3 (each within the scatter of the next).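

In this assay, (benzyloxycarbonyl)methyl in place of hydrogen on a saturated chain carbon bound to an aromatic nitrogen gives no change at the digits printed from compound 2 to compound 3 (within the scatter). This position therefore takes a group of 11 heavy atoms, including a six-membered aromatic ring of carbon only, with compound 3 level with compound 2. No supporting data bear on this result.

Open, on these data alone, is whether a carboxylic acid or an amine in place of (benzyloxycarbonyl)methyl would shift the read-out from this level. Also open, as far as these compounds go, is whether any group at this position separates from compound 2.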